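The source may report more compounds than this note shows. Statements on the series, on what has been measured and on what is new or still open speak of the compounds shown alone.

Measured so far:
- Compound 1 `O=C(Nc1cccc2cnccc12)NC1CCc2cc(F)ccc2C1Cc1ccccc1` gives 4 nM in an assay on HEK293 cells for displacement of a labelled ligand from transient receptor potential cation channel subfamily V member 1 (Homo sapiens); a lower number here means a stronger inhibitor, a higher number a weaker inhibitor.
- Compound 2 `O=C(Nc1cccc2cnccc12)NC1CCc2cc(Br)ccc2C1Cc1ccccc1` gives 2 nM in this assay.

Within the data shown here, compound 1 stands as the higher of these two numbers, but the only measured step, a 2.0-fold lower number from compound 1 to compound 2 (0.30 log units; within the scatter), lies within the scatter, so the two compounds cannot be told apart on these data.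

Compound 3 `O=C(Nc1cccc2cnccc12)NC1CCc2cc(F)ccc2C1Cc1ccoc1` differs from compound 1 by the change (furan-3-yl in place of phenyl on a saturated chain carbon bound to a saturated ring carbon). Put another way, a benzyl group becomes a (furan-3-yl)methyl group.

Among the measured compounds shown here, none of the measured steps bears on this part of the molecule. For the measured compounds named here, the single step available, a 2.0-fold lower number from compound 1 to compound 2 (0.30 log units; within the scatter), concerns a halogen on an aromatic carbon in the shared core and was itself within the scatter, so it gives neither a size nor a direction for the change to compound 3. Without a guide, a step in this assay of roughly a 2.0-fold higher number from compound 1 to compound 3 (0.30 log units; within the scatter) is expected, a move toward a slightly higher number that may well remain within the scatter. Compound 3 is therefore estimated at 8 nM, with a range from 2 nM to 30 nM.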

Compound 3, inhibition constant: 16 nM
Estimate against measurement, compound 3: 2.0-fold (0.30 log units) below; low and high end bracket the measured number.
By their numbers in this assay, from the lowest: compounds 2 and 1 (each within the scatter of the next); then compound 3.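

Among these compounds, this is the first measured change to the benzyl group, and in this assay replacing phenyl with furan-3-yl gives a 4.0-fold higher number from compound 1 to compound 3 (0.60 log units; beyond the scatter) as a modest step beyond the scatter. The earlier bromo-for-fluoro step stayed within the scatter, so this position is the first place in the series where a single change clearly moves the number, and the phenyl ring is shown not to be essential, since compound 3 still gives 16 nM in the same assay. Nothing measured here shows which part of the change, the five-membered ring or its oxygen, lies behind the higher number.

Going by these compounds, with only one replacement at this position, the ring size and the oxygen cannot be separated, and it remains open whether a thiophene ring, a pyridine ring or a cyclohexyl group would give a number closer to that of compound 1. On these data alone, it is also open whether the same change would have a similar effect on the bromo compound 2, so this single step cannot yet be treated as a general rule for the series.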